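The source may report more compounds than this note shows. Statements on the series, on what has been measured and on what is new or still open speak of the compounds shown alone.

Compound 1 `O=C(Nc1ccc(-c2ccccc2)cc1)c1cc([N+](=O)[O-])ccc1Cl`: > 27000 nM
Compound 2 `O=C(Nc1ccc(Cl)c(-c2nc3ccccc3s2)c1)c1cc([N+](=O)[O-])ccc1Cl`: > 25000 nM
Compound 3 `O=C(Nc1ccc(Cl)c(C(F)(F)F)c1)c1cc([N+](=O)[O-])ccc1Cl`: > 27000 nM

In an ADME assay on Raji cells (Homo sapiens) for cytotoxicity, with a stated time of 72 h (a higher number here means that more compound is needed for the effect, a lower number that less compound is needed), each entry above is a limit and not a number. Compound 3 therefore has no exact place on the scale, and its > 27000 nM is a limit too.

Compound 4 `O=C(Nc1ccc(Cl)cc1)c1cc([N+](=O)[O-])ccc1Cl` carries hydrogen in place of trifluoromethyl on an aromatic carbon, ortho to a chloro group: hydrogen in place of trifluoromethyl on an aromatic carbon.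

For the measured compounds named here, the only measured step at this place is a step that the two limits leave unreadable from compound 2 to compound 3, and it shows no size. No step beyond the scatter is therefore expected in this assay, and a further limit seems likely. The expected change is a number no higher from compound 3 to compound 4 (the limit leaves the size open). For compound 4 the estimate is 27000 nM, with an expected range from 12000 nM to 50000 nM.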

Compound 4, half-maximal effective concentration: > 27000 nM
Compound 4: only a limit was reported; the forecaster's own chance of this, stated with the estimate: 85%; the middle value sits exactly at the limit.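

Compound 4 is reported only as a limit, as are compound 1, compound 2 and compound 3, so its steps to these three cannot be read. The compounds shown leave open what exact value any of them has in this assay.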